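The compounds below may be only part of what the source reports. "The series", "measured", "known", "first", "only" and "open" are said of these compounds alone.

Measured so far in a functional assay on LoVo cells (Homo sapiens) for inhibition, read by colorimetric assay and MTT assay, with a stated time of 72 h; a higher number here means a weaker inhibitor, a lower number a stronger inhibitor:
- compound 1 `Cc1ccc2c(c1)-c1cnc(n1C)OCCCCCCCCO2` gives 34000 nM
- compound 2 `CCCCOc1ncc(-c2ccccc2OC)n1C` gives 39000 nM

Compound 2, at 39000 nM, stands level with compound 1 within the scatter of this assay, so these two numbers set no order. Among the compounds with values here, only two measured numbers exist, and the two compounds do not differ in one place. Within the data shown here, the series therefore offers no measured step to serve as a guide.

The next compound is compound 3 `C=CCCOc1ncc(-c2ccccc2OC)n1C`, not yet measured. Its change from compound 2 is vinyl in place of ethyl on a saturated chain carbon, two bonds along the chain from an oxygen on an aromatic ring. Cut one bond further out, the same difference reads butoxy to (but-3-en-1-yl)oxy.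

With no measurement of this change available, no shift beyond the scatter is expected in this assay, and no direction can be favoured. The expected change is a 1.1-fold lower number from compound 2 to compound 3 (0.03 log units; within the scatter). For compound 3 the estimated value is 36000 nM, with an expected range from 16000 nM to 75000 nM.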

Compound 3, half-maximal inhibitory concentration: 24000 nM
Compound 3: middle estimate off by 1.5-fold (0.18 log units), on the high side; measured number inside the range.
By their numbers in this assay, from the lowest: compounds 3, 1 and 2 (each within the scatter of the next).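

In this assay, the series now has its first measured step at this position: vinyl in place of ethyl on a saturated chain carbon, two bonds along the chain from an oxygen on an aromatic ring, gives a 1.6-fold lower number from compound 2 to compound 3 (0.21 log units; within the scatter). Going from butoxy to (but-3-en-1-yl)oxy, and so adding one double bond outside aromatic rings, therefore leaves compound 3 level with compound 2 in this assay, and this single pair shows no measurable effect of that change on the read-out. No supporting measurement bears on this result, so the step stands as an observation without an explanation.

The compounds shown leave open whether a different group at this same place, such as a longer chain, an amine or a carboxylic acid, would move the number beyond the scatter of this assay, since ethyl and vinyl are the only two groups compared here. Within the data shown here, compound 1 differs from compound 2 and compound 3 in more than one place, so no step to it can be read, and what its core contributes remains unresolved.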